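Removing the Phenyl from Compound 3: An Expected Cytotoxicity

A few compounds are considered here, and "the series" means these few. Any claim that something is new, unique, unknown or untested is made for them only; others in the source may bear on it.

Compound 1 `COc1ccc(CN2C(=O)c3cccnc3C2=O)cc1OC` gives a limit of > 100000 nM in an ADME assay on Vero cells (Chlorocebus sabaeus) for cytotoxicity; a higher number here means a weaker inhibitor, a lower number a stronger inhibitor.
Compound 2 `O=C1c2nccnc2C(=O)N1Cc1ccccc1` gives a limit of > 100000 nM in this assay.
Compound 3 `C[C@H](c1ccccc1)N1C(=O)c2nccnc2C1=O` gives 79000 nM in this assay.

For the measured compounds named here, compound 3 holds the only true number among the three; the other two values are limits, and the limit of > 100000 nM in this assay, at which 2 of the 3 values shown sit, describes where they sit. Compound 4 `CCN1C(=O)c2nccnc2C1=O` differs from compound 3 by hydrogen in place of phenyl on a saturated chain carbon bound to an amide-type nitrogen in a ring and a saturated chain carbon. Going by the values given here, the only measured step is an at least 1.2-fold lower number from compound 2 to compound 3 (0.10 log units; that floor lies within the scatter), which falls within the scatter and concerns a methyl entering at a different kind of place, so it says little about removing a phenyl. Among the compounds with values here, nothing among the measured compounds points to a change beyond the scatter in either direction, and a result at the assay limit is quite possible. The step from compound 3 to compound 4 is therefore expected to be a 1.2-fold higher number from compound 3 to compound 4 (0.08 log units; within the scatter), a change not beyond the scatter. Compound 4 is thus estimated to give about 95000 nM, with a likely range from 40000 nM to 250000 nM.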

Compound 4, half-maximal inhibitory concentration: > 100000 nM
Compound 4: a limit, no number; the forecaster's own chance of this, stated with the estimate: 55%; at least 1.0-fold (0.02 log units) between middle value and limit.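

Replacing the phenyl with hydrogen on this saturated chain carbon gives an at least 1.2-fold higher number from compound 3 to compound 4 (0.10 log units; that floor lies within the scatter) in this assay, and this is the first sign that the phenyl can be removed without a change shown to lie beyond the scatter. Compound 4 gives a limit rather than a number, leaving only a floor for this step and no true size, and the step from compound 2 to compound 4 cannot be read at all. For the compounds shown here, compound 3 remains the only compound here with a true number, and the other three sit together at a single limit: the limit of > 100000 nM in this assay, at which 3 of the 4 values shown sit.

Going by these compounds, it remains open whether a different group on this carbon, such as an amine or a longer chain, would give a true number in this assay. On these data alone, how far compound 1, compound 2 and compound 4 truly differ from one another also remains unknown.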